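Working notes: compound 4 as a thioether variant of compound 1

This account rests on a few compounds, and the source may have more. Where it says the series, first, only, none or still open, it means among the compounds named here.

Values in a functional assay on Jurkat cells (Homo sapiens) for inhibition; on this read-out lower numbers stand for stronger inhibition and higher numbers for weaker inhibition:
Compound 1, `CCOC(=O)c1c(C)noc1OCC(=O)[C@H](CC(=O)O)NC(=O)[C@@H](NC(=O)COc1cccc2ccccc12)C(C)C`: > 200000 nM, a limit of the assay.
Compound 2, `CC(C)c1cc(OCC(=O)[C@H](CC(=O)O)NC(=O)[C@@H](NC(=O)COc2cccc3ccccc23)C(C)C)no1`: > 200000 nM, a limit of the assay.
Compound 3, `CC(C)[C@H](NC(=O)COc1cccc2ccccc12)C(=O)N[C@@H](CC(=O)O)C(=O)CSc1nccn1C`: > 200000 nM, a limit of the assay.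

Compound 1 stands only at a limit, and the same holds for the other two: the limit of > 200000 nM in this assay, at which 3 of the 3 values shown sit. The steps a step that the two limits leave unreadable from compound 1 to compound 2 and a step that the two limits leave unreadable from compound 1 to compound 3 therefore have no readable size.

Compound 4 is `CC(C)[C@H](NC(=O)COc1cccc2ccccc12)C(=O)N[C@@H](CC(=O)O)C(=O)CSc1nc2ccccc2s1`; it differs from compound 1 as follows: (1,3-benzothiazol-2-yl)sulfanyl in place of (4-(ethoxycarbonyl)-3-methyl-1,2-oxazol-5-yl)oxy on a saturated chain carbon bound to a carbonyl carbon. The step to compound 3 is the closest comparison, a sulfanyl group entering at the same place, yet its size is not readable, so no direction can be expected in this assay. Compound 4 is estimated at 200000 nM (range 50000 nM to 400000 nM), an expected step of a number no higher from compound 1 to compound 4 (the limit leaves the size open), most probably again reported as a limit.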

Compound 4, half-maximal inhibitory concentration: > 200000 nM
Compound 4: only a limit was reported (the forecaster's own chance of this, stated with the estimate: 70%); the middle value sits exactly at the limit.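

Going by these compounds alone, no step from compound 4 to compound 1, compound 2 or compound 3 can be read, since all four values are limits of the assay: the limit of > 200000 nM in this assay, at which 4 of the 4 values shown sit.

The compounds shown leave open whether any group on the saturated chain carbon bound to a carbonyl carbon gives a readable value in this assay.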